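A phenyl swap from compound 3 to compound 4

The compounds below may be only part of what the source reports. "The series", "measured", "known", "first", "only" and "open" are said of these compounds alone.

compound 1 `Cc1cc(=O)c2c(O)cc(OCc3ccc([N+](=O)[O-])cc3)c([C@H]3CCN(C)C[C@H]3O)c2o1`: 23%
compound 2 `Cc1cc(=O)c2c(O)cc(OC/C=C/c3ccccc3)c([C@H]3CCN(C)C[C@H]3O)c2o1`: 18%
compound 3 `Cc1oc2c([C@H]3CCN(C)C[C@H]3O)c(O)cc(O)c2c(=O)c1C(O)c1cccc(Cl)c1`: 31%

These values come from a functional assay on PC-3 cells (Homo sapiens) for inhibition, read by MTT assay, with a stated time of 48 h, tested at 10 uM; a higher number here means more inhibition of growth at the concentration tested, a lower number less inhibition of growth. Compound 3 (31%) holds the highest number of the three, but its gap to compound 1 lies within the scatter, and only its gap to compound 2 lies beyond it.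

Compound 4 `Cc1oc2c([C@H]3CCN(C)C[C@H]3O)c(O)cc(O)c2c(=O)c1C(O)c1ccc(F)c(Br)c1` differs from compound 3 in one group: 3-bromo-4-fluorophenyl in place of 3-chlorophenyl on a saturated chain carbon bound to an aromatic carbon and an oxygen on a saturated carbon. The group sits on a saturated chain carbon bound to an aromatic carbon and an oxygen on a saturated carbon.

Among the compounds with values here, the only measured step, a number 5 percentage points lower from compound 1 to compound 2 (within the scatter), lies at another place and says little here. Within the data shown here, no step at this place has been measured, so no shift beyond the scatter is expected. The expected step is a number 1 percentage points higher from compound 3 to compound 4 (within the scatter) in this assay. For compound 4 the estimated value is 32%, with an expected range from 18% to 47%.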

Compound 4, percent growth inhibition at one concentration: 72%
Compound 4: the middle estimate sits 40 percentage points below what was measured; the whole stated range lies below it.
By their numbers in this assay, from the lowest: compounds 2, 1 and 3 (each within the scatter of the next, the first and the last beyond it); then compound 4.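

In this assay, within the data shown here, the step of a number 41 percentage points higher from compound 3 to compound 4 (beyond the scatter) is the first measured at this place, and it shows that the result is highly sensitive to the halogens on this phenyl ring. Exchanging 3-chlorophenyl for 3-bromo-4-fluorophenyl is enough to produce this large step beyond the scatter. Nothing available explains the rise.

From the compounds shown here alone, since the bromine and the fluorine enter together, the share of each in the step remains open. Going by these compounds, it is also open whether a ring carrying an amine or a carboxylic acid instead of halogens would keep this gain.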